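Chalcone-bearing pyrazolopyrimidines: a para-methyl variant

This account rests on a few compounds, and the source may have more. Where it says the series, first, only, none or still open, it means among the compounds named here.

Measured compounds and values in an ADME assay on HEK293 cells (Homo sapiens) for antiproliferative activity, read by MTT assay, with a stated time of 24 h; a higher number here means a weaker inhibitor, a lower number a stronger inhibitor:
compound 1 `COc1ccc(-c2cc(C(=O)/C=C/c3ccccc3)nc3cc(-c4ccccc4)nn23)cc1OC` — 64100 nM
compound 2 `COc1ccc(-c2cc(/C=C/C(=O)c3cc(OC)c(OC)c(OC)c3)nc3cc(-c4ccccc4)nn23)cc1OC` — 35000 nM
compound 3 `COc1cc(-c2cc(C(=O)/C=C/c3ccc(Cl)cc3)nc3cc(-c4ccccc4)nn23)cc(OC)c1OC` — 53900 nM

In this assay compound 1 gives 64100 nM, and compounds 2 and 3 both return numbers within the usual scatter of that value, so the three cannot be ordered on these data alone.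

The untested analogue compound 4 `COc1ccc(-c2cc(C(=O)/C=C/c3ccc(C)cc3)nc3cc(-c4ccccc4)nn23)cc1OC` differs from compound 1 in one place: methyl in place of hydrogen on an aromatic carbon. Going by the values given here, no step between measured compounds of the same kind is available. The expectation is no change beyond the scatter, with an estimated step of a 1.2-fold lower number from compound 1 to compound 4 (0.07 log units; within the scatter). For compound 4 the expected value in this assay is 55000 nM, with a range from 25000 nM to 120000 nM.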

Compound 4, half-maximal inhibitory concentration: 57400 nM
For compound 4 the middle estimate is 1.0-fold (0.02 log units) below the measured one, within the range that was stated.
By their numbers in this assay, from the lowest: compounds 2, 3, 4 and 1 (each within the scatter of the next).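

In this assay, going by these compounds alone, methyl in place of hydrogen on an aromatic carbon, para to a large group, gives a 1.1-fold lower number from compound 1 to compound 4 (0.05 log units; within the scatter), the first comparison between compounds differing in one place. At this position, phenyl to 4-methylphenyl therefore shows no step beyond the scatter. No evidence on hand bears on this result.

Open, going by these compounds, is whether an amine, a carboxylic acid or a longer chain in the same place would give a step beyond the scatter. Also open, on these data alone, is whether methyl in place of hydrogen gives a similar step on other members.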